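Amide nitrogen methylation in the dihydroxyheptanoic acid series

The source may report more compounds than this note shows. Statements on the series, on what has been measured and on what is new or still open speak of the compounds shown alone.

Two compounds carry the shared core with a dihydroxy acid side chain and have been measured in an assay on microsomes from liver for inhibition of 3-hydroxy-3-methylglutaryl-coenzyme A reductase (Rattus norvegicus); on this read-out lower numbers stand for stronger inhibition and higher numbers for weaker inhibition. Compound 1 `CC(C)c1c(C(=O)N(C)Cc2cccc(F)c2)nn(-c2ccc(F)cc2)c1CC[C@@H](O)C[C@@H](O)CC(=O)O` gives 4.1 nM. Compound 2 `Cc1cccc(CNC(=O)c2nn(-c3ccc(F)cc3)c(OC[C@@H](O)C[C@@H](O)CC(=O)O)c2C(C)C)c1` gives 4.9 nM. Compound 2 holds the higher of the two numbers, but its gap to compound 1 lies within the scatter, so the two compounds cannot be ordered on these values.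

The next compound, compound 3 `Cc1cccc(CN(C)C(=O)c2nn(-c3ccc(F)cc3)c(OC[C@@H](O)C[C@@H](O)CC(=O)O)c2C(C)C)c1`, is taken from compound 2 by a single change: methyl in place of hydrogen on an amide-type nitrogen. Going by the values given here, no measured pair with this same change exists, so the step cannot be read from a neighbour. What can be said is that compound 1 also carries methyl on an amide-type nitrogen and gives 4.1 nM, which does not point to a penalty for that substitution.

The step of a 1.1-fold lower number from compound 2 to compound 3 (0.04 log units; within the scatter) is therefore expected to be small, without a clear direction, and not beyond the scatter. For compound 3 the estimated value in this assay is 4.5 nM, with a range from 1.8 nM to 11 nM.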

Compound 3, half-maximal inhibitory concentration: 37 nM
Compound 3: the middle estimate sits 8.2-fold (0.91 log units) below what was measured; the whole stated range lies below it.
By their numbers in this assay, from the lowest: compounds 1 and 2 (each within the scatter of the next); then compound 3.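

On this amide-type nitrogen, the position does not accept every substitution without consequence: in this assay, methyl in place of hydrogen gives a 7.6-fold higher number from compound 2 to compound 3 (0.88 log units; beyond the scatter), a step beyond the scatter from a change of a single heavy atom, carrying the (3-methylbenzyl)carbamoyl group to methyl(3-methylbenzyl)carbamoyl. Methyl on such a nitrogen is therefore not neutral in the setting of compound 3, although compound 1, which also carries methyl there, gives 4.1 nM; compound 1 differs from compound 3 in more than one place, so this value says nothing direct about the step and cannot be set against it. No measurement on hand gives a reason for the step.

From the compounds shown here alone, it remains open whether the same change would produce a step of similar size on the core of compound 1, which would require its counterpart with the amide hydrogen. Also open, going by these compounds, is how the read-out responds on this nitrogen to ethyl, a longer chain or a cyclopropyl group in place of methyl, and so whether the step follows the size of the group or is specific to methyl.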